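Sulfonyl aryl swap on the shared core: compound 4

This account rests on a few compounds, and the source may have more. Where it says the series, first, only, none or still open, it means among the compounds named here.

Of the compounds shown here, three have been measured in an assay on isolated protein for displacement of a labelled ligand from metabotropic glutamate receptor 5 (Homo sapiens), with a stated time of 60 min, tested at 1 uM; on this read-out lower numbers stand for less inhibition and higher numbers for more inhibition at the one concentration tested (going by the name of the read-out). Compound 1 `COc1ccc(S(=O)(=O)c2cnc3ccc(C)cc3c2N2CCC(C)CC2)cc1Cl` gives 93%, compound 2 `CC1CCN(c2c(S(=O)(=O)c3cc(Cl)cc(Cl)c3)cnc3ccc(F)cc23)CC1` gives 69%, and compound 3 `Cc1ccc(S(=O)(=O)c2cnc3ccc(F)cc3c2N2CCC(C)CC2)cc1F` gives 86%. Compound 3 stands second of the three: compound 1 lies above it within the scatter, and compound 2 lies below it beyond the scatter. Within the data shown here, the one single-point step measured so far, a number 17 percentage points higher from compound 2 to compound 3 (beyond the scatter), comes from the exchange of 3,5-dichlorophenyl for 3-fluoro-4-methylphenyl on the sulfonyl sulfur, so the group on that sulfur does move the read-out in this assay.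

Compound 4 `COc1ccc(S(=O)(=O)c2cnc3ccc(F)cc3c2N2CCC(C)CC2)cc1Cl` has not been measured. It differs from compound 3 in one place: 3-chloro-4-methoxyphenyl in place of 3-fluoro-4-methylphenyl on a sulfonyl sulfur. Compound 4 thereby carries the same 3-chloro-4-methoxyphenyl on the sulfonyl sulfur as compound 1, while the rest of the molecule is that of compound 3. Among the measured compounds shown here, the step from compound 2 to compound 3 bears on the change only in that it shows this position matters; no measured pair isolates the present exchange. With compound 1 at 93% and compound 3 at 86% both high, the expected step of a number 4 percentage points higher from compound 3 to compound 4 (within the scatter) is small and within the scatter. Compound 4 is therefore estimated at 90%, with a range from 80% to 97%.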

Compound 4, a percentage reported as inhibition, at one concentration (the size of the read-out at that concentration, not a potency): 82%
Compound 4: the middle estimate sits 8 percentage points above what was measured, within the range that was stated.
By their numbers in this assay, from the lowest: compound 2; then compounds 4, 3 and 1 (each within the scatter of the next, the first and the last beyond it).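

In this assay, the exchange on the sulfonyl sulfur gives a number 4 percentage points lower from compound 3 to compound 4 (within the scatter), so 3-chloro-4-methoxyphenyl and 3-fluoro-4-methylphenyl cannot be told apart on this read-out, even though they differ in substituents and the entering group carries a hydrogen-bond acceptor that the leaving group lacks. Against 3,5-dichlorophenyl, the same exchange gives a number 13 percentage points higher from compound 2 to compound 4 (beyond the scatter); together with a number 17 percentage points higher from compound 2 to compound 3 (beyond the scatter), this places both of the other aryl groups beyond 3,5-dichlorophenyl, a statement that holds for these three compounds only. The series also now has its first step outside the sulfonyl aryl group, with fluoro in place of methyl on an aromatic carbon giving a number 11 percentage points lower from compound 1 to compound 4 (beyond the scatter), which shows that the read-out responds to that place as well.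

Nothing available here accounts for any of these steps. Still open, on these data alone, is whether a nitrile on that aromatic carbon, or a carboxylic acid or an amine on the aryl group of the sulfonyl sulfur, would keep the read-out at this level, and whether the fluoro-for-methyl step holds with other groups on the sulfur.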